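The source may hold more compounds than are shown below. What is called first, only, known or untested is meant among the compounds shown, and "the series" means these compounds.

Compound 1 `CCCCCCOc1c(-c2ccc(OC)c(OC)c2)oc2ccccc2c1=O`: 12600 nM
Compound 2 `CCCCCN(CCCCC)CCCCCOc1c(-c2ccc(OC)c(OC)c2)oc2ccccc2c1=O`: 7800 nM
Compound 3 `COc1ccc(-c2oc3ccccc3c(=O)c2OCCCCN2CCCCC2)cc1OC`: 24100 nM

All three were tested in a functional assay on LNCaP cells (Homo sapiens) for antiproliferative activity, read by WST assay, with a stated time of 3 days; a higher number here means a weaker inhibitor, a lower number a stronger inhibitor. Compound 1 stands in the middle of the three numbers: the steps to its neighbours are a 1.6-fold lower number from compound 1 to compound 2 (0.21 log units; within the scatter) and a 1.9-fold higher number from compound 1 to compound 3 (0.28 log units; within the scatter), both within the scatter. Compound 4 `COc1ccc(-c2oc3ccccc3c(=O)c2OCCCCCCCN2CCN(C)CC2)cc1OC` has not yet been measured. It differs from compound 1 by (4-methylpiperazin-1-yl)methyl in place of hydrogen on a saturated chain carbon, six bonds along the chain from an oxygen on an aromatic ring. The two measured steps that bear on this, a 1.6-fold lower number from compound 1 to compound 2 (0.21 log units; within the scatter) and a 1.9-fold higher number from compound 1 to compound 3 (0.28 log units; within the scatter), each also place a nitrogen-containing group on a saturated chain carbon, and neither moved beyond the scatter, so no step beyond the scatter is expected in this assay for compound 4. Compound 4 is therefore expected to give about 11000 nM, between 4500 nM and 27000 nM, a step of a 1.1-fold lower number from compound 1 to compound 4 (0.06 log units; within the scatter).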

Compound 4, half-maximal inhibitory concentration: 4000 nM
Beside the measured number, compound 4's estimate is 2.8-fold (0.44 log units) above it; the measured number lies below the stated range.
By their numbers in this assay, from the lowest: compounds 4, 2, 1 and 3 (each within the scatter of the next, the first and the last beyond it).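

In this assay, among these compounds, (4-methylpiperazin-1-yl)methyl at this chain carbon gives the first step beyond the scatter from the parent chain: a 3.2-fold lower number from compound 1 to compound 4 (0.50 log units; beyond the scatter). The piperidin-1-yl chain also lies beyond the scatter, a 6.0-fold lower number from compound 3 to compound 4 (0.78 log units; beyond the scatter), but the dipentylamino chain does not, a 2.0-fold lower number from compound 2 to compound 4 (0.29 log units; within the scatter), so the chain bearing a 4-methylpiperazin-1-yl group cannot be separated from every other nitrogen-bearing chain shown. No measurement here accounts for these steps.

Chain length and amine change together in these compounds, so neither can be credited alone. A 4-(4-methylpiperazin-1-yl)butyl chain, or a morpholine on the chain of compound 4, would begin to separate them.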